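The source may hold more compounds than are shown below. What is called first, only, known or untested is meant among the compounds shown, and "the series" means these compounds.

Measured so far in a functional assay on Gurav cells (Homo sapiens) for inhibition, read by sulforhodamine B assay; a lower number here means a stronger inhibitor of growth, a higher number a weaker inhibitor of growth
- compound 1 `FC(F)(F)c1ccc(-c2ccc(-c3ccc(-c4nc5ccccc5[nH]4)cc3)cc2)cc1` gives 39100 nM
- compound 2 `Oc1cccc2[nH]c(-c3ccc(-c4ccc(-c5ccc(F)cc5)cc4)cc3)nc12` gives 2860 nM

Compound 2 has the lower number of the two, and its gap to compound 1 lies beyond the scatter. Compound 3 `Oc1cccc2[nH]c(-c3ccc(-c4ccc(-c5ccc(C(F)(F)F)cc5)cc4)cc3)nc12` keeps the rest of compound 2 and changes one group, with trifluoromethyl in place of fluoro on an aromatic carbon, para to a large group. The counted difference is trifluoromethyl in place of fluoro on an aromatic carbon and the change reads as 4-fluorophenyl to 4-(trifluoromethyl)phenyl. For the measured compounds named here, no measured pair shows this change on its own, so the expectation rests on little. A small rise in the number in this assay is expected, which may not go beyond the scatter. The anchor is compound 2 at 2860 nM while compound 1, which also carries trifluoromethyl, at 39100 nM leaves room upward. The expected move is a 1.4-fold higher number from compound 2 to compound 3 (0.15 log units; within the scatter) as estimated from these two values. Compound 3 is estimated at 4000 nM with an expected range from 1500 nM to 12000 nM in this assay.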

Compound 3, concentration for 50% growth inhibition: 3190 nM
Compound 3: the middle estimate sits 1.3-fold (0.10 log units) above what was measured, and the stated range covers the measured number.
By their numbers in this assay, from the lowest: compounds 2 and 3 (each within the scatter of the next); then compound 1.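

In this assay, trifluoromethyl in place of fluoro on an aromatic carbon, para to a large group, gives a 1.1-fold higher number from compound 2 to compound 3 (0.05 log units; within the scatter), so at this position the two groups cannot be told apart despite the larger heavy-atom count of trifluoromethyl. For the compounds shown here, compound 3 also gives the first reading of hydroxy in place of hydrogen on an aromatic carbon as a single-place change: with trifluoromethyl held constant, a 12-fold lower number from compound 1 to compound 3 (1.09 log units; beyond the scatter) is a large step, whereas compounds 1 and 2 differ in two places and could not isolate it. Nothing available explains the size of either step.

On these data alone, the hydroxy step is read only with trifluoromethyl, so its size with fluoro at that position remains open, as does whether a methoxy group or an amine in place of the hydroxy would keep the lower number. As far as these compounds go, it also remains open whether the equivalence of fluoro and trifluoromethyl extends to a nitrile, a carboxylic acid or a longer chain at the same position.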